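From a Charged Ring Side Chain to a Small Urea

This account rests on a few compounds, and the source may have more. Where it says the series, first, only, none or still open, it means among the compounds named here.

Compound 1 `COc1ccc(-c2nc(/N=C(\N)[N+]3(C)CCCCC3)sc2-c2ccc(OC)cc2)cc1`: > 1000 nM
Compound 2 `COc1ccc(-c2nc(/N=C(\N)N3CCOCC3)sc2-c2ccc(OC)cc2)cc1`: < 1000 nM
Compound 3 `COc1ccc(-c2nc(CNC(=O)CSc3ccccc3)sc2-c2ccc(OC)cc2)cc1`: < 100 nM

In a functional assay with Oryctolagus cuniculus as the target (on this read-out higher numbers stand for weaker inhibition and lower numbers for stronger inhibition), compound 1 sits at a limit of the assay, not at a number. Compound 2 and compound 3 also sit at limits, and each of those limits is lower. Compound 4 `CNC(=O)NCc1nc(-c2ccc(OC)cc2)c(-c2ccc(OC)cc2)s1` keeps the shared core of compound 1 and changes the side chain: a group of 6 heavy atoms (3 carbon, 2 nitrogen, 1 oxygen; no ring) in place of a group of 10 heavy atoms (7 carbon, 3 nitrogen; one six-membered non-aromatic ring with 1 hetero atom), on an aromatic carbon. For the measured compounds named here, the only measured step touching this side chain is a number no higher from compound 1 to compound 2 (the limit leaves the size open), which points downward but leaves its size open. Compound 3, whose side chain likewise carries no net charge, sits at the limit of < 100 nM in this assay, at which 1 of the 3 values shown sits. A downward step is therefore expected, an at least 3.3-fold lower number from compound 1 to compound 4 (0.52 log units; beyond the scatter), and compound 4 is estimated at 300 nM, between 60 nM and 1500 nM.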

Compound 4, half-maximal inhibitory concentration: 22 nM
Compound 4: the middle estimate sits 14-fold (1.13 log units) above what was measured, and the stated range ends above it.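

In this assay, at this position on the shared core, the ((methylcarbamoyl)amino)methyl group, with no ring and no net charge, gives an at least 45-fold lower number from compound 1 to compound 4 (1.65 log units; beyond the scatter) and the only exact number among these compounds. For compound 1, > 1000 nM is a limit of the assay, not a number. The steps from compound 2 and from compound 3 to compound 4 cannot be read.

Nothing shown gives a cause for the step or separates losing the net charge from losing the ring. From the compounds shown here alone, how an amine or a carboxylic acid in place of this group, or a longer chain on its urea nitrogen, would read in this assay stays open.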